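This account rests on a few compounds, and the source may have more. Where it says the series, first, only, none or still open, it means among the compounds named here.

In a functional assay on PC-3 cells (Homo sapiens) for cytotoxicity, read by MTT assay, with a stated time of 72 h (a lower number here means a stronger inhibitor, a higher number a weaker inhibitor), compound 1, whose structure is `COc1ccc(NC(=O)COC(=O)/C=C/c2cc(OC)c(OCc3ccc(Cl)c(Cl)c3)c(OC)c2)cc1`, reaches only the limit of the assay, > 200000 nM, and not a number. Compound 2, with the structure `COc1cc(/C=C/C(=O)OCC(=O)Nc2ccc(Cl)cc2)cc(OC)c1OCc1ccc(Cl)c(Cl)c1`, likewise gives in this assay only the limit > 200000 nM. Compound 3, `O=C(COC(=O)/C=C/c1ccc(O)c(O)c1)Nc1ccc(Cl)cc1`, is the one of the three that yields a number, 160000 nM in this assay. The difference between the core of compound 3 and the core of compound 2 is not broken down here.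

Compounds 2 and 1 differ in one place: methoxy in place of chloro on an aromatic carbon. The step is a step that the two limits leave unreadable from compound 2 to compound 1, so the two measured values give no size for this change.

Compound 4, `COc1ccc(NC(=O)COC(=O)/C=C/c2ccc(O)c(O)c2)cc1`, has not yet been measured. It differs from compound 3 by the same change, (methoxy in place of chloro on an aromatic carbon), at a place described in the same words as before. For compound 4 in this assay the expected step is a 1.1-fold higher number from compound 3 to compound 4 (0.05 log units; within the scatter), set beside the earlier one. This expectation rests on the unreadable a step that the two limits leave unreadable from compound 2 to compound 1 and on (the limit of > 200000 nM in this assay, at which 2 of the 3 values shown sit), which together give no sign of a direction for this change and leave the value of compound 3 as the only anchor. The value of compound 4 is therefore estimated at 180000 nM, with a range from 80000 nM to 400000 nM, and with a real chance that only a limit is reported again.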

Compound 4, half-maximal inhibitory concentration: 172000 nM
Compound 4: middle estimate off by 1.0-fold (0.02 log units), on the high side; measured number inside the range.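

On the core of compound 3, going from 4-chlorophenyl to 4-methoxyphenyl is a 1.1-fold higher number from compound 3 to compound 4 (0.03 log units; within the scatter), so in this assay the two groups cannot be told apart on this core. The same change on the core of compound 2 leads to compound 1, but that step cannot be read, and so nothing here shows whether the result on the first core carries over to the second: the limit of > 200000 nM in this assay, at which 2 of the 4 values shown sit. What remains is a single readable pair, which shows how this change behaves on one core and cannot serve as a rule for the series, nor say what the change would do on a core where it could be measured more widely.

Within the data shown here, open is what an amine or a carboxylic acid at this same place on the ring would do to the number in this assay, since chloro and methoxy are the only two groups seen there. Also open, as far as these compounds go, is whether a longer chain in place of the methoxy group, such as a butoxy chain, would separate itself from these two compounds by more than the usual scatter of the assay.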